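Coumarin imine sulfonamides: guanidine to dimethylpyrimidinyl swap

This account rests on a few compounds, and the source may have more. Where it says the series, first, only, none or still open, it means among the compounds named here.

Two imine-linked coumarin sulfonamides have numbers in a functional assay on MCF7 cells (Homo sapiens) for cytotoxicity, read by CCK-8 assay, with a stated time of 48 h; on this read-out higher numbers stand for weaker inhibition and lower numbers for stronger inhibition. Compound 1 `Cc1cc(C)nc(NS(=O)(=O)c2ccc(/N=C/c3c(Cl)c4ccccc4oc3=O)cc2)n1` gives 20 nM. Compound 2 `Cc1ccc2oc(=O)c(/C=N/c3ccc(S(=O)(=O)NC(=N)N)cc3)c(Cl)c2c1` gives 67 nM. Going by the values given here, compound 2 thus holds the higher of the two numbers, and compound 1 sits clearly lower, beyond the scatter; no single-point step links the two, since they differ in both the sulfonamide substituent and the methyl on the coumarin.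

Compound 3 `Cc1ccc2oc(=O)c(/C=N/c3ccc(S(=O)(=O)Nc4nc(C)cc(C)n4)cc3)c(Cl)c2c1` is to be measured in this assay. Relative to compound 2 the change is a group of 8 heavy atoms (6 carbon, 2 nitrogen; one six-membered aromatic ring with 2 hetero atoms) in place of a group of 3 heavy atoms (1 carbon, 2 nitrogen; no ring), on a sulfonamide nitrogen. Compound 3 carries the same sulfonamide substituent as compound 1, so the expectation rests on compound 1 giving 20 nM. The step expected from compound 2 to compound 3 is a 2.7-fold lower number from compound 2 to compound 3 (0.43 log units; beyond the scatter), toward stronger inhibition and beyond the scatter. Compound 3 is estimated at 25 nM, with a range from 10 nM to 65 nM.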

Compound 3, half-maximal inhibitory concentration: 25 nM
Beside the measured number, compound 3's estimate shows no gap at the digits printed; the range from low to high includes it.
By their numbers in this assay, from the lowest: compounds 1 and 3 (each within the scatter of the next); then compound 2.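

In this assay, going by these compounds alone, a 4,6-dimethylpyrimidin-2-yl group on the sulfonamide nitrogen gives (a 2.7-fold lower number from compound 2 to compound 3 (0.43 log units; beyond the scatter)) with the rest of the structure held constant, which is the first single-place reading at this position. Within the data shown here, the methyl on an aromatic carbon of the shared core, read alone for the first time, gives (a 1.3-fold higher number from compound 1 to compound 3 (0.10 log units; within the scatter)), so this step does not separate the pair. Nothing shown bears on the reason for the step at the sulfonamide nitrogen.

A single ring substituent appears on that nitrogen, so a pyrimidin-2-yl group without its two methyl groups, a phenyl or an acetyl group would be needed to show whether the ring or its methyl groups carry the step. On these data alone, whether the group leaving compound 2 gives the same step on the core of compound 1 also remains open.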